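Permeability notes on a diamine series

This account rests on a few compounds, and the source may have more. Where it says the series, first, only, none or still open, it means among the compounds named here.

Compound 2 `c1ccc(CCc2ccc3c(NCCCNCc4ccco4)ccnc3c2)cc1` is one of two measured members of the series. In an ADME assay for permeability, using PAMPA, with a stated time of 30 min, at pH 7.4 (on this read-out higher numbers stand for higher permeability and lower numbers for lower permeability), compound 2 gives 23 10^-6 cm/s. Compound 1 `COc1cccc(CNCCCNc2ccnc3cc(Cc4ccc(F)cc4)ccc23)c1O` is the other measured member; in this assay compound 1 gives 23 10^-6 cm/s. Compound 2 therefore stands level with compound 1 at the digits shown, within the scatter, and no order between the two can be read from these numbers.

Compound 3 `COc1cccc(CNCCCNc2ccnc3cc(CCc4ccccc4)ccc23)c1O` is not yet measured. It differs from compound 2 in one place: 2-hydroxy-3-methoxyphenyl in place of furan-2-yl on a saturated chain carbon bound to an amine nitrogen. Among the compounds with values here, the same change, cut one bond further out, reads (furan-2-yl)methyl to 2-hydroxy-3-methoxybenzyl, and the group that enters is the one already present in compound 1.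

Within the data shown here, no step between measured compounds is available, so the step to compound 3 has no direct precedent. Compound 1, which carries the entering group, gives 23 10^-6 cm/s in this assay, and that reading is the main ground for expecting no shift beyond the scatter. The step from compound 2 to compound 3 is expected to be a 1.0-fold lower number from compound 2 to compound 3 (0.02 log units; within the scatter). Compound 3 is estimated at 22 10^-6 cm/s, with a range from 11 10^-6 cm/s to 44 10^-6 cm/s.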

Compound 3, apparent permeability: 23 10^-6 cm/s
Compound 3: the middle estimate sits 1.0-fold (0.02 log units) below what was measured; the measured number falls inside the stated range.
By their numbers in this assay, from the lowest: compounds 1, 2 and 3 (each within the scatter of the next).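

In this assay, within the data shown here, the change to 2-hydroxy-3-methoxyphenyl in place of furan-2-yl on a saturated chain carbon bound to an amine nitrogen gives no change at the digits printed from compound 2 to compound 3 (within the scatter) and is the first direct reading at this position, where a group of 5 heavy atoms with 0 hydrogen-bond donors gives way to one of 9 heavy atoms with 1 hydrogen-bond donor. The other end of the molecule now has a direct reading too: benzyl in place of 4-fluorophenyl on a saturated chain carbon bound to an aromatic carbon gives no change at the digits printed from compound 1 to compound 3 (within the scatter) and so adds a second change that the read-out does not resolve. Both single changes in this set of three compounds stay within the scatter, no compound goes against that, and no measurement is at hand that would account for it.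

Still open, from the compounds shown here alone, is whether this holds for groups of another kind at the amine end, such as a benzoic acid carrying a carboxylic acid or a piperidine ring in place of the aromatic ring. Also open, going by these compounds, is whether a longer chain joining the amine nitrogen to the shared core, or an amide in place of the amine, would leave the reading where these three compounds stand.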